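The source may hold more compounds than are shown below. What is called first, only, known or untested is meant among the compounds shown, and "the series" means these compounds.

Measured compounds:
- compound 1, `COc1ccccc1Nc1nc(SCc2cn(CC(=O)NC(=O)Nc3ccccn3)nn2)nc(-c2ccc(C(C)C)cc2)c1C#N`: > 64000 nM in a functional assay on MGC-803 cells (Homo sapiens) for inhibition, read by MTT assay, with a stated time of 72 h; on this read-out higher numbers stand for weaker inhibition and lower numbers for stronger inhibition (a limit of this assay, not a number)
- compound 2, `COc1ccccc1Nc1nc(SCc2cn(CC(=O)NC(=O)Nc3ccccn3)nn2)nc(-c2ccc(C)cc2)c1C#N`: 7960 nM
- compound 3, `CC(C)c1ccc(Nc2nc(SCc3cn(CC(=O)NC(=O)Nc4ccccn4)nn3)nc(-c3ccc(Cl)cc3)c2C#N)cc1`: 16900 nM

Compound 1 gives only a limit in this assay, (the limit of > 64000 nM in this assay, at which 1 of the 3 values shown sits), so its value is not a number. Compound 2 differs from compound 1 in one place, (methyl in place of isopropyl on an aromatic carbon), and the step that this change made is an at least 8.0-fold lower number from compound 1 to compound 2 (0.90 log units; beyond the scatter). Compound 3 gives 16900 nM in this assay, a higher number than compound 2; the difference between the cores of compound 1 and compound 3 is not broken down here.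

Compound 4, `Cc1ccc(Nc2nc(SCc3cn(CC(=O)NC(=O)Nc4ccccn4)nn3)nc(-c3ccc(Cl)cc3)c2C#N)cc1`, is not yet measured. It differs from compound 3 as methyl in place of isopropyl on an aromatic carbon. This is the same change as from compound 1 to compound 2, on the same kind of place, though in compound 3 the ring that carries the isopropyl belongs to the (4-isopropylphenyl)amino part, whereas in compound 1 it is the 4-isopropylphenyl part. The earlier step is only a lower bound, since compound 1 sits at a limit, so the expected size from compound 3 to compound 4 is taken as a lower number of similar or somewhat smaller size, a 4.2-fold lower number from compound 3 to compound 4 (0.63 log units; beyond the scatter), with wide uncertainty because the change now sits on the other aromatic ring. Compound 4 is therefore expected to give about 4000 nM in this assay, estimated between 1500 nM and 12000 nM.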

Compound 4, half-maximal inhibitory concentration: 24000 nM
Compound 4: middle estimate off by 6.0-fold (0.78 log units), on the low side; measured number outside the range, above it.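

In this assay, methyl in place of isopropyl in the (4-isopropylphenyl)amino part gives a 1.4-fold higher number from compound 3 to compound 4 (0.15 log units; within the scatter), so the change does not carry over from the earlier pair to this one: the same change on two cores in this assay, an at least 8.0-fold lower number (0.90 log units; beyond the scatter) from compound 1 to compound 2 and a 1.4-fold higher number (0.15 log units; within the scatter) from compound 3 to compound 4, at least 11-fold (1.05 log units) apart, beyond the scatter of two such steps

Compound 1 gives a limit of the assay and not a number, so the earlier step has only a lower bound: the limit of > 64000 nM in this assay, at which 1 of the 4 values shown sits.

These two pairs do not show whether the gap comes from the aromatic ring that carries the change or from another difference between the two cores, and two pairs set no rule for any further core in the series.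

Open, on these data alone, is how the same place would read with an ethyl or a tert-butyl group, or with a more different group such as an amine or a carboxylic acid. Also open, as far as these compounds go, is whether the change gives the same step when the 4-isopropylphenyl and (4-isopropylphenyl)amino parts are compared on otherwise matched cores, which would separate the ring that carries the change from the remaining differences between the cores.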